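The compounds below may be only part of what the source reports. "The series", "measured", "known", "first", "only" and "open" are said of these compounds alone.

Compound 1 `Nc1scc(CN2CCN(c3ccc(Cl)cc3Cl)CC2)c1C(=O)c1ccc(Cl)cc1`: 2%
Compound 2 `COc1ccc(N2CCN(Cc3csc(N)c3C(=O)c3ccc(Cl)cc3)CC2)cc1`: -1.2%
Compound 3 `Nc1scc(CN2CCN(c3ccncc3)CC2)c1C(=O)c1ccc(Cl)cc1`: -4%

These three compounds share one core and differ only in the group attached to an amine nitrogen in a ring. In a functional assay on CHO cells with adenosine receptor A1 (Homo sapiens) as the target, read by cAMP accumulation and immunoassay, with a stated time of 6 min, tested at 0.01 uM (a lower number here means a stronger effect, a higher number a weaker effect of the compound at the concentration tested), compound 2 stands second highest of the three numbers, with compound 3 nearest and compound 1 furthest, and all three lie close to zero. The unmeasured compound 4 `Nc1scc(CN2CCN(c3c(F)cc(F)cc3F)CC2)c1C(=O)c1ccc(Cl)cc1` arises from compound 2 by a single exchange on that same nitrogen: 2,4,6-trifluorophenyl in place of 4-methoxyphenyl on an amine nitrogen in a ring. The measured steps that bear on this exchange each swap the group on this nitrogen: a number 3.2 percentage points lower from compound 1 to compound 2 (within the scatter), a number 6 percentage points lower from compound 1 to compound 3 (within the scatter) and a number 2.8 percentage points lower from compound 2 to compound 3 (within the scatter). None of them shifted the read-out beyond the scatter, even though the groups exchanged were quite different from one another. The step expected from compound 2 to compound 4 in this assay is therefore none beyond the scatter, a number 2.2 percentage points higher from compound 2 to compound 4 (within the scatter). Compound 4 is estimated to give about 1%, within an expected range from -8% to 10%.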

Compound 4, a percentage reported as activity, at one concentration (the size of the read-out at that concentration, not a potency): 4.2%
For compound 4 the middle estimate is 3.2 percentage points below the measured one; low and high end bracket the measured number.
By their numbers in this assay, from the lowest: compounds 3, 2, 1 and 4 (each within the scatter of the next).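

In this assay, the 2,4,6-trifluorophenyl group brings fluorine onto the ring on the amine nitrogen, and it carries no hydrogen-bond acceptor, unlike the 4-methoxyphenyl group it replaces. Even so, all three new steps stay within the scatter (a number 5.4 percentage points higher from compound 2 to compound 4 (within the scatter)), (a number 8.2 percentage points higher from compound 3 to compound 4 (within the scatter)) and (a number 2.2 percentage points higher from compound 1 to compound 4 (within the scatter)). Among these compounds, this position has now held four different aromatic rings, with or without halogens, and no step among compounds 1, 2, 3 and 4 is printed as beyond the scatter.

From the compounds shown here alone, all four compounds carry an aromatic ring on this nitrogen, so it remains open whether a benzyl group, a simple alkyl chain or an acetyl group would give a similar read-out. The data shown give no measured reason why these exchanges leave the read-out within the scatter.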